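This account rests on a few compounds, and the source may have more. Where it says the series, first, only, none or still open, it means among the compounds named here.

Among the measured compounds shown here, compound 3 `CCNC(=O)Nc1ccc(S(=O)(=O)Oc2ccccc2C(C)C)cc1` gives 10000 nM in a functional assay on MCF7 cells (Homo sapiens) for antiproliferative activity, read by sulforhodamine B assay, with a stated time of 48 h (on this read-out lower numbers stand for stronger inhibition and higher numbers for weaker inhibition), the second highest of the three numbers so far. Compound 1 `CC(=O)Nc1ccc(S(=O)(=O)Oc2ccccc2C(C)C)cc1`, at 16000 nM, lies nearest: a 1.6-fold lower number from compound 1 to compound 3 (0.20 log units; within the scatter). Compound 2 `CC(C)c1ccccc1OS(=O)(=O)c1ccc(NC(=O)CCl)cc1`, at 2900 nM, lies furthest: a 3.4-fold higher number from compound 2 to compound 3 (0.54 log units; beyond the scatter); compare a 5.5-fold lower number from compound 1 to compound 2 (0.74 log units; beyond the scatter). Compound 4 `CCCNC(=O)Nc1ccc(S(=O)(=O)Oc2ccccc2C(C)C)cc1` differs from compound 3 by methyl in place of hydrogen on a saturated chain carbon, two bonds along the chain from an amide-type nitrogen. For the measured compounds named here, no measured step lengthens a chain this way; both measured steps swap the group on the carbonyl carbon, and only the chloromethyl group moved the number beyond the scatter, as compound 3 shows against compound 1 because a 1.6-fold lower number from compound 1 to compound 3 (0.20 log units; within the scatter) stayed within it. A methyl added to the ethyl of compound 3 is therefore expected to give no step beyond the scatter, a 1.1-fold lower number from compound 3 to compound 4 (0.05 log units; within the scatter). Compound 4 is expected at 9000 nM, within 4000 nM to 20000 nM.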

Compound 4, half-maximal inhibitory concentration: 2700 nM
Estimate against measurement, compound 4: 3.3-fold (0.52 log units) above; measured number outside the range, below it.
By their numbers in this assay, from the lowest: compounds 4 and 2 (each within the scatter of the next); then compounds 3 and 1 (each within the scatter of the next).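

In this assay the change from ethyl to propyl gives a 3.7-fold lower number from compound 3 to compound 4 (0.57 log units; beyond the scatter), so one methyl on this saturated chain carbon moves the number beyond the scatter. Propylamino on the carbonyl carbon gives a 5.9-fold lower number from compound 1 to compound 4 (0.77 log units; beyond the scatter), whereas ethylamino stayed within the scatter of methyl. Among the compounds shown here, it also gives a 1.1-fold lower number from compound 2 to compound 4 (0.03 log units; within the scatter), so chloromethyl is no longer the only group on this carbon to reach this range, and nothing at hand accounts for the step.

On these data alone, whether a butyl chain continues the trend from ethyl to propyl remains open. A branched isopropyl group or a cyclic amine at this place is equally unresolved.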